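The source may report more compounds than this note shows. Statements on the series, on what has been measured and on what is new or still open speak of the compounds shown alone.

The series was examined in an ADME assay on MT2 cells (Homo sapiens) for cytotoxicity, read by MTT assay; a higher number here means that more compound is tolerated, a lower number that less compound is tolerated. Compound 1 `Cc1cc(Oc2ccccc2OCCn2ccc(=O)[nH]c2=O)c2cc(C#N)[nH]c2c1` gives 1200 nM in this assay. Compound 2 `N#Cc1cc2c(Oc3ccc(F)cc3OCCn3ccc(=O)[nH]c3=O)cccn2c1`, built on a different core, gives 100000 nM in this assay. Compound 3 `N#Cc1ccc2c(Oc3ccc(Cl)cc3OCCn3ccc(=O)[nH]c3=O)cccc2c1` stands apart in that its result is a limit of the assay and not a number, > 100000 nM in this assay. Compound 3 therefore sits at the limit of > 100000 nM in this assay, at which 1 of the 3 values shown sits, the only one of the three measured compounds to do so.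

The step followed here leads from compound 3 to compound 4 `N#Cc1ccc2c(Oc3ccc(F)cc3OCCn3ccc(=O)[nH]c3=O)cccc2c1`. The two structures differ in one place: fluoro in place of chloro on an aromatic carbon. For the measured compounds named here, no measured pair in this set shares that change, so no step of its kind is known from these data, and what the two values of compound 2 and compound 3 show is only that both lie at the high end of the range covered in this assay.

Going by the values given here, with no measured step of this kind to build on, the change from compound 3 to compound 4 is expected to give a step of a number no higher from compound 3 to compound 4 (the limit leaves the size open), that is, none beyond the usual scatter. Compound 4 is accordingly estimated at 100000 nM in this assay, with a range from 40000 nM to 200000 nM, and a real chance that the assay again reports only a limit.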

Compound 4, half-maximal cytotoxic concentration: > 100000 nM
Compound 4: a limit, no number; the forecaster's own chance of this, stated with the estimate: 50%; the middle value lies on the limit itself.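

Compound 3 and compound 4 both return only a limit and not a number in this assay, so fluoro in place of chloro gives no step that can be read between them: the limit of > 100000 nM in this assay, at which 2 of the 4 values shown sit.

The compounds shown leave open how far either compound lies past that limit, and whether this change shifts tolerance at all.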